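The source may report more compounds than this note shows. Statements on the series, on what has been measured and on what is new or still open speak of the compounds shown alone.

Measured compounds:
compound 1 `CCCn1c(=O)[nH]c2nc(-c3ccc(S(=O)(=O)N4CCN(C)CC4)cc3)[nH]c2c1=O` — in an assay on CHO cells for displacement of a labelled ligand from adenosine receptor A3 (Homo sapiens), read by scintillation counting, with a stated time of 45 min, tested at 1 uM, in the presence of a further agent that is not named here (on this read-out lower numbers stand for less inhibition and higher numbers for more inhibition at the one concentration tested (going by the name of the read-out)), compound 1 gives 7%;
compound 2 `CCCn1c(=O)[nH]c2nc(-c3ccc(S(=O)(=O)N4CCN(Cc5cccc(Br)c5)CC4)cc3)[nH]c2c1=O` — compound 2 gives 23%;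
compound 3 `CCCn1c(=O)[nH]c2nc(-c3ccc(S(=O)(=O)N4CCN(c5ccccc5F)CC4)cc3)[nH]c2c1=O` — compound 3 gives 9%.

Compound 3 stands second highest of these three numbers: the step of a number 2 percentage points higher from compound 1 to compound 3 (within the scatter) is within the scatter, while a number 14 percentage points lower from compound 2 to compound 3 (beyond the scatter) is the wider gap. Compound 4 `CCCn1c(=O)[nH]c2nc(-c3ccc(S(=O)(=O)N4CCN(c5ccc(C)cc5)CC4)cc3)[nH]c2c1=O` differs from compound 3 in one place: 4-methylphenyl in place of 2-fluorophenyl on an amine nitrogen in a ring. Among the compounds with values here, no measured step exchanges one aromatic group for another on this ring nitrogen, so the guidance is indirect. The closest comparison is a number 2 percentage points higher from compound 1 to compound 3 (within the scatter), where an aromatic group entered at that nitrogen without a change beyond the scatter; a number 16 percentage points higher from compound 1 to compound 2 (beyond the scatter) shows a modest rise for a different group there. A step of a number 2 percentage points higher from compound 3 to compound 4 (within the scatter) is therefore expected, none beyond the scatter. Compound 4 is estimated at 11% in this assay, between 3% and 22%.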

Compound 4, a percentage reported as inhibition, at one concentration (the size of the read-out at that concentration, not a potency): 25%
The estimate for compound 4 lay 14 percentage points below the measured number; measured number above the stated range.
By their numbers in this assay, from the lowest: compounds 1 and 3 (each within the scatter of the next); then compounds 2 and 4 (each within the scatter of the next).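

At this ring nitrogen, the choice of aromatic group matters: (in this assay) there is a number 16 percentage points higher from compound 3 to compound 4 (beyond the scatter) even though the two groups have the same heavy-atom count. The 4-methylphenyl group also stands clear of methyl, with a number 18 percentage points higher from compound 1 to compound 4 (beyond the scatter), while a number 2 percentage points higher from compound 2 to compound 4 (within the scatter) leaves it level with 3-bromobenzyl. Nothing available explains the difference between the two aromatic groups.

From the compounds shown here alone, it remains open whether the fluorine-to-methyl exchange or the changed place on the phenyl ring accounts for the rise. A 4-fluorophenyl or 2-methylphenyl group on this nitrogen could separate the two.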